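Chain homologues on a shared triazole-bearing core in mice

The compounds below may be only part of what the source reports. "The series", "measured", "known", "first", "only" and "open" are said of these compounds alone.

Measured so far:
compound 1, `CCCCCCOc1ccc(-n2cnnc2CCC)cc1`: 5.7 mg/kg
compound 2, `CCCCCCOc1ccc(-n2cnnc2CCCC)cc1`: 13.6 mg/kg
compound 3, `CCCCCCOc1ccc(-n2cnnc2CCCCCC)cc1`: > 40 mg/kg

Three compounds share one core and differ only in the length of one saturated chain. In a functional assay on the whole organism (strain C57B/6) with Mus musculus as the target, in the maximal electroshock model (a lower number here means that less compound is needed, a higher number that more compound is needed for the effect), compound 1 gives 5.7 mg/kg. Compound 2 differs from compound 1 by methyl in place of hydrogen on a saturated chain carbon, three bonds along the chain from an aromatic carbon, and this change gives a 2.4-fold higher number from compound 1 to compound 2 (0.38 log units; beyond the scatter). Compound 3 differs from compound 1 by propyl in place of hydrogen on a saturated chain carbon, three bonds along the chain from an aromatic carbon, and the step is an at least 7.0-fold higher number from compound 1 to compound 3 (0.84 log units; beyond the scatter). From compound 2 onward the step is an at least 2.9-fold higher number from compound 2 to compound 3 (0.46 log units; beyond the scatter). For compound 3 the value of > 40 mg/kg is a limit of this assay, not a number, as shown by the limit of > 40 mg/kg in this assay, at which 1 of the 3 values shown sits.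

Compound 4, `CCCCCCCc1nncn1-c1ccc(OCCCCCC)cc1`, is not yet measured. It differs from compound 3 by methyl in place of hydrogen on a saturated chain carbon, six bonds along the chain from an aromatic carbon. Within the data shown here, this is the same kind of change as the one from compound 1 to compound 2, with the difference that here the methyl enters on a saturated chain carbon six bonds along the chain from an aromatic carbon, whereas there it entered three bonds along the chain.

Because compound 3 already sits at > 40 mg/kg, compound 4 is expected to lie at or past that limit. The step that the limit leaves unreadable from compound 3 to compound 4 is estimated to match or exceed the earlier one, resting on a 2.4-fold higher number from compound 1 to compound 2 (0.38 log units; beyond the scatter) and an at least 2.9-fold higher number from compound 2 to compound 3 (0.46 log units; beyond the scatter). The expected value for compound 4 is 80 mg/kg, between 40 mg/kg and 200 mg/kg.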

Compound 4, dose for half-maximal effect: > 40 mg/kg
Compound 4: no number, only a limit; the forecaster's own chance of this, stated with the estimate: 85%; the middle value does not contradict the limit.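

In this assay compound 4 gives > 40 mg/kg, which is a limit of the assay and not a number. Set against the two shorter chains, the result reads as an at least 2.9-fold higher number from compound 2 to compound 4 (0.46 log units; beyond the scatter) and as an at least 7.0-fold higher number from compound 1 to compound 4 (0.84 log units; beyond the scatter), whereas the step from compound 3 to compound 4 cannot be read, since both of its ends are limits. Propyl in place of hydrogen, three bonds along the chain from an aromatic carbon in one case and four bonds along it in the other, raises the number in both cases, so the direction of the change carries over, but the size of the change cannot be compared: the same change on two cores in this assay, an at least 7.0-fold higher number (0.84 log units; beyond the scatter) from compound 1 to compound 3 and an at least 2.9-fold higher number (0.46 log units; beyond the scatter) from compound 2 to compound 4; the limit leaves it open whether they differ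

The compounds shown leave open how far past the limit compound 3 and compound 4 lie, and so whether lengthening the chain still changes anything at this end of the series: the limit of > 40 mg/kg in this assay, at which 2 of the 4 values shown sit. Also open is how this assay would read for a chain shorter than the one in compound 1, such as ethyl or methyl, or for a chain ending in an amine or a carboxylic acid on the shared core.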